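The compounds below may be only part of what the source reports. "The series", "measured", "known", "first", "only" and "open" are said of these compounds alone.

Measured so far in a functional assay on HeLa cells (Homo sapiens) for cytotoxicity, read by MTT assay, with a stated time of 48 h; a higher number here means a weaker inhibitor, a lower number a stronger inhibitor:
compound 1 `O=C(Nc1nc2ccc(Cl)cc2s1)c1cc(-c2ccc(F)cc2)n2nc(-c3ccccc3)cc2n1`: 9770 nM
compound 2 `COc1ccc(-c2cc(C(=O)Nc3nc4ccc(Cl)cc4s3)nc3cc(-c4ccccc4)nn23)cc1OC`: 9120 nM
compound 3 `COc1cc(-c2cc(C(=O)Nc3nc4ccc(Cl)cc4s3)nc3cc(-c4ccccc4)nn23)cc(OC)c1OC`: 22400 nM

Compound 2 gives the lowest of the three numbers in this assay, but the gap to compound 1 is small: a 1.1-fold lower number from compound 1 to compound 2 (0.03 log units; within the scatter). The gap to compound 3 is wider: a 2.5-fold higher number from compound 2 to compound 3 (0.39 log units; beyond the scatter), and in the same sense a 2.3-fold higher number from compound 1 to compound 3 (0.36 log units; beyond the scatter). All three measured steps exchange the aryl group that carries the fluoro or methoxy substituents; the (6-chloro-1,3-benzothiazol-2-yl)amino part of the shared core is common to all of them.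

Compound 4 `COc1ccc(-c2cc(C(=O)Nc3nc4ccc(F)cc4s3)nc3cc(-c4ccccc4)nn23)cc1OC` differs from compound 2 exactly there: fluoro in place of chloro on an aromatic carbon. Going by the values given here, no measured step covers a change at this position, so nothing in this assay speaks for a shift in either direction, and the whole series so far sits within a modest band in this assay. The step is therefore expected to stay inside the scatter: a 1.1-fold higher number from compound 2 to compound 4 (0.04 log units; within the scatter) is the expected change from compound 2 to compound 4. Compound 4 is expected to give 10000 nM in this assay, with a range from 4000 nM to 25000 nM.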

Compound 4, half-maximal inhibitory concentration: 8310 nM
The estimate for compound 4 lay 1.2-fold (0.08 log units) above the measured number, and the stated range covers the measured number.
By their numbers in this assay, from the lowest: compounds 4, 2 and 1 (each within the scatter of the next); then compound 3.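

In this assay, going by these compounds alone, the replacement of 6-chloro-1,3-benzothiazol-2-yl by 6-fluoro-1,3-benzothiazol-2-yl gives the first reading at this position of the shared core, with a 1.1-fold lower number from compound 2 to compound 4 (0.04 log units; within the scatter). The earlier steps shown here changed only the aryl group carrying the fluoro or methoxy substituents, whereas this one shows that, with the 3,4-dimethoxyphenyl group in place, the chloro and fluoro compounds cannot be told apart in this cell read-out, so the exchange of these two halogens on the aromatic carbon has no effect that can be resolved here. No supporting measurement bears on the reason for this result.

On these data alone, because the halogen exchange is read on this one aryl background only, it remains open whether fluoro and chloro would also read alike alongside the 4-fluorophenyl group of compound 1 or the 3,4,5-trimethoxyphenyl group of compound 3. The compounds shown also leave open whether an amine, a carboxylic acid or a longer alkyl chain in place of the halogen would move the number beyond the scatter, so the tolerance of this position is known only for chloro and fluoro.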